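Lipophilicity notes: hydroxyethyl amide to ring-bearing amide

The source may report more compounds than this note shows. Statements on the series, on what has been measured and on what is new or still open speak of the compounds shown alone.

Measured so far in a physicochemical assay for lipophilicity; on this read-out lower numbers stand for lower lipophilicity and higher numbers for higher lipophilicity

compound 1 `CNC(=O)c1cc(C(=O)N[C@H]2[C@@H]3C[C@@H](OC)C[C@@H]32)n([C@@H](C)c2ccccc2)n1` gives 2.7
compound 2 `CNC(=O)c1cc(C(=O)NCCO)n([C@@H](C)c2ccccc2)n1` gives 2.4
compound 3 `CNC(=O)c1cc(C(=O)N[C@H]2[C@@H]3C[C@@H](O)C[C@@H]32)c([C@@H](C)c2ccccc2)o1` gives 2.8

Compound 2 stands within the scatter of compound 1 and beyond the scatter of compound 3. Compound 4 `CNC(=O)c1cc(C(=O)N[C@H]2[C@@H]3C[C@@H](O)C[C@@H]32)n([C@@H](C)c2ccccc2)n1` differs from compound 2 in one place: a group of 7 heavy atoms (6 carbon, 1 oxygen; one three-membered non-aromatic ring of carbon only, one five-membered non-aromatic ring of carbon only) in place of a group of 3 heavy atoms (2 carbon, 1 oxygen; no ring), on an amide-type nitrogen stands on the amide-type nitrogen. For the measured compounds named here, the one measured step bearing on this is a number 0.30 log units lower from compound 1 to compound 2 (within the scatter) and compound 1 carries a close relative of the entering group. Read in reverse, that step suggests a small rise at most. In this assay the expected step is a number 0.10 log units higher from compound 2 to compound 4 (within the scatter) and it stays within the scatter. Compound 4 is estimated at 2.5 with 2.2 to 2.8 as the expected range.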

Compound 4, distribution coefficient: 3.2
Compound 4: middle estimate off by 0.70 log units, on the low side; measured number outside the range, above it.
By their numbers in this assay, from the lowest: compounds 2, 1 and 3 (each within the scatter of the next, the first and the last beyond it); then compound 4.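

In this assay, the amide-type nitrogen proves sensitive: the ring-bearing group in place of 2-hydroxyethyl gives a number 0.80 log units higher from compound 2 to compound 4 (beyond the scatter) and so goes beyond the scatter, which the step with the methyl ether in compound 1 did not. The methyl on the oxygen also matters, since hydrogen in its place gives a number 0.50 log units higher from compound 1 to compound 4 (beyond the scatter) on the same ring-bearing group. No measurement here accounts for either step.

Open, from the compounds shown here alone, is whether a longer chain bearing a terminal hydroxyl on this nitrogen tracks compound 2 or compound 4. Also open, going by these compounds, is how an amine or a carboxylic acid in place of the hydroxyl on the ring-bearing group would read.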